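Acetylated diterpenoid esters: cytotoxicity notes on three analogues

The source may report more compounds than this note shows. Statements on the series, on what has been measured and on what is new or still open speak of the compounds shown alone.

Measured so far in a toxicity assay on HEK-293T cells (Homo sapiens) for cytotoxicity, read by MTT assay, with a stated time of 48 h; a lower number here means a stronger inhibitor, a higher number a weaker inhibitor:

- compound 1 `C=C1[C@H](OC(C)=O)[C@@H](OC(=O)C(C)(C)C)[C@@H](OC(C)=O)C(C)(C)/C=C/[C@H](C)[C@H](OC(=O)c2ccccc2)[C@@]2(O)C[C@@](C)(OC(C)=O)[C@H](OC(C)=O)[C@@H]2[C@H]1OCC(C)C`: 18900 nM
- compound 2 `C=C1[C@H](OC(C)=O)[C@@H](OC(=O)c2cccc(C)c2)[C@@H](OC(C)=O)C(C)(C)/C=C/[C@H](C)[C@H](OC(=O)c2ccccc2)[C@@]2(O)C[C@@](C)(OC(C)=O)[C@H](OC(C)=O)[C@@H]2[C@H]1OCC(C)C`: 7600 nM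
- compound 3 `C=C1[C@H](OC(C)=O)[C@@H](OC(C)=O)[C@@H](OC(C)=O)C(C)(C)/C=C/[C@H](C)[C@H](OC(=O)c2ccccc2)[C@@]2(O)C[C@@](C)(OC(=O)C(C)(C)C)[C@H](OC(C)=O)[C@@H]2[C@H]1OCC(C)C`: 56300 nM

Compound 3 gives the highest number of the three; compound 1 stands nearest to it and compound 2 furthest, both gaps lying beyond the usual scatter. Compound 1 and compound 3 have the same atoms joined differently; the difference between the two cores is not broken down here.

Between compound 1 and compound 2 the change is 3-methylphenyl in place of tert-butyl on a carbonyl carbon, and the step in this assay is a 2.5-fold lower number from compound 1 to compound 2 (0.40 log units; beyond the scatter).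

Compound 4 `C=C1[C@H](OC(C)=O)[C@@H](OC(C)=O)[C@@H](OC(C)=O)C(C)(C)/C=C/[C@H](C)[C@H](OC(=O)c2ccccc2)[C@@]2(O)C[C@@](C)(OC(=O)c3cccc(C)c3)[C@H](OC(C)=O)[C@@H]2[C@H]1OCC(C)C` is not yet measured. It differs from compound 3 by 3-methylphenyl in place of tert-butyl on a carbonyl carbon, the same change, made at a place described in the same words as before.

Among the compounds with values here, the step from compound 3 to compound 4 in this assay is expected to be a 2.3-fold lower number from compound 3 to compound 4 (0.37 log units; beyond the scatter), an estimate that rests on the single earlier instance of this change because of a 2.5-fold lower number from compound 1 to compound 2 (0.40 log units; beyond the scatter). One instance is a narrow base, so the range is kept wide. Compound 4 is accordingly expected to give 24000 nM, between 10000 nM and 60000 nM.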

Compound 4, half-maximal inhibitory concentration: 7220 nM
Compound 4: the middle estimate sits 3.3-fold (0.52 log units) above what was measured, outside the stated range (below it).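

In this assay, 3-methylphenyl in place of tert-butyl on a carbonyl carbon gives a 7.8-fold lower number from compound 3 to compound 4 (0.89 log units; beyond the scatter), the same direction as on the core of compound 1. The direction carries from one core to the other in these two instances, but the size does not: the same change on two cores in this assay, a 2.5-fold lower number (0.40 log units; beyond the scatter) from compound 1 to compound 2 and a 7.8-fold lower number (0.89 log units; beyond the scatter) from compound 3 to compound 4, 3.1-fold (0.50 log units) apart, beyond the scatter of two such steps. This shows that the size of the step from one core cannot be carried unchanged to the other in this series, but it does not show which structural difference between the cores accounts for the gap, and two instances cannot establish a rule for any further core.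

The compounds shown leave open whether a plain phenyl, a longer alkyl chain or a 3-methylphenyl replaced by a ring carrying an amine or a carboxylic acid would lower the number in the same direction at this carbonyl. Also open, from the compounds shown here alone, is whether the aromatic ring itself matters here, which a cyclohexyl ester on both cores would help to separate.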